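The source may hold more compounds than are shown below. What is called first, only, known or untested is meant among the compounds shown, and "the series" means these compounds.

Working notes on the series in a functional assay on L1210 cells (Mus musculus) for inhibition; a lower number here means a stronger inhibitor, a higher number a weaker inhibitor. Three compounds carry numbers or a limit here. Compound 1 `Nc1nc(=O)n(COCCO)cc1[N+](=O)[O-]` gives 71 ug/mL in this assay. Compound 2 `O=c1cc(O)ccn1COCCO` reaches only a limit of this assay, > 1000 ug/mL, and no number is reported for it. One of the three values thus sits at the limit of > 1000 ug/mL in this assay, at which 1 of the 3 values shown sits. Compound 3 `Nc1nc2c(nc(Cl)n2COCCO)c(=O)[nH]1` gives 350 ug/mL in this assay, the highest of the two numbers shown; compound 1 lies lower by a gap that is beyond the usual scatter, and no further comparison of measured pairs is available.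

Compound 4 `Nc1nc2c(nc(I)n2COCCO)c(=O)[nH]1` is the next member to be run. It differs from compound 3 only in one place: iodo in place of chloro on an aromatic carbon. Among the compounds with values here, no measured step of this kind exists in the set, so the size of the change cannot be read from a neighbour. The expectation is that the step from compound 3 to compound 4 in this assay stays within the scatter, with no direction claimed, that is a 1.2-fold lower number from compound 3 to compound 4 (0.07 log units; within the scatter). Compound 4 is therefore estimated at 300 ug/mL in this assay, with a range from 120 ug/mL to 800 ug/mL.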

Compound 4, concentration for 50% inhibition: 39 ug/mL
The estimate for compound 4 lay 7.7-fold (0.89 log units) above the measured number, outside the stated range (below it).
By their numbers in this assay, from the lowest: compounds 4 and 1 (each within the scatter of the next); then compound 3. At a limit, above all of these: compound 2.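

In this assay, within the data shown here, iodo in place of chloro on an aromatic carbon gives a 9.0-fold lower number from compound 3 to compound 4 (0.95 log units; beyond the scatter) as the first measured step. The position, on the five-membered aromatic ring between two ring nitrogen atoms, is therefore not indifferent to which halogen it carries: one heavy atom replaces one heavy atom, with no hydrogen-bond donor, hydrogen-bond acceptor or net charge entering or leaving, and the number still moves beyond the scatter. Nothing measured in the set bears on what lies behind this step.

Open, on these data alone, is how bromo, fluoro or an amine on this carbon would compare with compound 4 at 39 ug/mL in this series. Also open, as far as these compounds go, is whether the step holds with a longer chain in place of the (2-hydroxyethoxy)methyl group.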